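The compounds below may be only part of what the source reports. "The series", "measured", "known", "first", "only" and "open" are said of these compounds alone.

Compound 1, `CC1(C)COC(=O)CCCCCCCCCCCCCCCOC(=O)C2CCCCN2C(=O)C1=O`: 11000000 nM in an assay on isolated protein for inhibition of peptidyl-prolyl cis-trans isomerase FKBP4 (Homo sapiens); a lower number here means a stronger inhibitor, a higher number a weaker inhibitor. Compound 2, `CC1(C)COC(=O)CCCCCCCCCOC(=O)[C@@H]2CCCCN2C(=O)C1=O`: 30000 nM in this assay.

Of the two measured compounds, compound 2 has the lower number, and compound 1 the higher. Compound 3, `CC1(C)COC(=O)CCCCCCCCCOC(=O)C2CCCCN2C(=O)C1=O`, differs from compound 2 only in drawn stereochemistry: the two compounds have the same atoms and bonds; at least one stereo element is drawn with a configuration in one of them and without one in the other: 1 of 1 stereo elements differ; a stereocentre at a saturated ring carbon is drawn S in compound 2 and without a configuration in compound 3. Since compound 2 itself is the drawn S form, compound 3 is expected to give a similar or somewhat higher number, with the step from compound 2 to compound 3 estimated at a 1.7-fold higher number from compound 2 to compound 3 (0.22 log units; within the scatter). Compound 3 is accordingly estimated at 50000 nM, within a range from 15000 nM to 200000 nM.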

Compound 3, inhibition constant: 90000 nM
Estimate against measurement, compound 3: 1.8-fold (0.26 log units) below; measured number inside the range.
By their numbers in this assay, from the lowest: compound 2; then compound 3; then compound 1.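

For the compounds shown here, the new result gives the first step between compounds that differ in one place: in this assay, leaving the configuration undrawn at the saturated ring carbon gives a 3.0-fold higher number from compound 2 to compound 3 (0.48 log units; beyond the scatter). The drawn S form thus has the lower number, by a modest margin beyond the scatter. The step rests on a single difference: the fact that one of compounds 2 and 3 is drawn with a defined configuration and the other without, at the place where they differ

As far as these compounds go, what a drawn R form would give at this stereocentre stays open. So does the effect of a shorter chain, or of an amide in place of either ester.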